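The source may report more compounds than this note shows. Statements on the series, on what has been measured and on what is new or still open speak of the compounds shown alone.

Working notes on the aminothienopyridine ketone series. Compound 1 `CC(C)(C)C(=O)c1sc2nc(-c3cccs3)ccc2c1N` carries a tert-butyl on the carbonyl carbon; in a functional assay on WI-38 VA13 cells (Homo sapiens) for cytotoxicity (a higher number here means that more compound is needed for the effect, a lower number that less compound is needed), compound 1 gives 0.57 ug/mL. Compound 2 `Nc1c(C(=O)c2ccc(F)c(F)c2)sc2nc(-c3cccs3)ccc12` has a 3,4-difluorophenyl in that place. Its result in this assay is a limit only: compound 2 gives > 4 ug/mL. Among the measured compounds shown here, the one measured step, an at least 7.0-fold higher number from compound 1 to compound 2 (0.84 log units; beyond the scatter), is therefore known only as a floor; it rests on the fact that compound 2 sits at the limit of > 4 ug/mL in this assay, at which 1 of the 2 values shown sits, so the true size of the step is open. Compound 3 `Nc1c(C(=O)c2ccc(Br)cc2)sc2nc(-c3cccs3)ccc12` changes the aryl group: 4-bromophenyl in place of 3,4-difluorophenyl on a carbonyl carbon. For the measured compounds named here, only the step from compound 1 to compound 2 bears on this, and it concerns a different exchange, alkyl for aryl; aryl for aryl has no measured precedent here. The expectation is that compound 3 stays close to compound 2, with a step that the limit leaves unreadable from compound 2 to compound 3 in this assay and a fair chance of another limit. Compound 3 is estimated at 6 ug/mL, range 2 ug/mL to 20 ug/mL.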

Compound 3, half-maximal effective concentration: 2.8 ug/mL
For compound 3 the middle estimate is 2.1-fold (0.33 log units) above the measured one, within the range that was stated.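

The exchange of an alkyl group for an aryl group on a carbonyl carbon now has a full measured size in this assay, not only a floor: a 4.9-fold higher number from compound 1 to compound 3 (0.69 log units; beyond the scatter). The exchange of one aryl group for another also has a first reading, an at least 1.4-fold lower number from compound 2 to compound 3 (0.15 log units; that floor lies within the scatter), which gives no evidence of a real difference between 4-bromophenyl and 3,4-difluorophenyl. The true size of that step stays unreadable because compound 2 rests on a limit: the limit of > 4 ug/mL in this assay, at which 1 of the 3 values shown sits.

The aryl groups shown are only these two halogen-bearing phenyl rings, so it remains open how an unsubstituted phenyl, a 4-methoxyphenyl or a pyridine ring would read in this assay. On these data alone, it is equally open how a smaller alkyl group, such as methyl or cyclopropyl, would compare with the tert-butyl of compound 1.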